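Two Chloro Groups on the Benzoxazole Core

The source may report more compounds than this note shows. Statements on the series, on what has been measured and on what is new or still open speak of the compounds shown alone.

Measured so far:
compound 1 `Cc1cccc2nc(N3CCN(C)CC3)oc12` gives 5.48
compound 2 `Cc1cc(Cl)cc2nc(N3CCN(C)CC3)oc12` gives 6.7
compound 3 `Cc1cc(C)c2oc(N3CCN(C)CC3)nc2c1` gives 6.32

Three measured compounds share one core and differ only on the six-membered aromatic ring. In a functional assay on ileum (strain Hartley) for agonist activity at 5-hydroxytryptamine receptor 3A (Cavia porcellus) (a higher number here means a more potent compound, by a factor of ten per unit of this negative logarithm, a lower number a less potent compound), compound 2 gives the highest number of the three: the step of a number 0.38 log units lower from compound 2 to compound 3 (beyond the scatter) lies beyond the scatter, and the step of a number 1.22 log units higher from compound 1 to compound 2 (beyond the scatter) is large.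

Compound 4 `CN1CCN(c2nc3cc(Cl)cc(Cl)c3o2)CC1` is the next compound. Its change from compound 2 is chloro in place of methyl on an aromatic carbon, on an aromatic carbon of the six-membered ring, ortho to a fused ring and meta to the chloro group already present.

Which measured steps bear on this? The swap between methyl and chloro is seen once, at a different position: a number 0.38 log units lower from compound 2 to compound 3 (beyond the scatter), where methyl in place of chloro lowered the number by a modest amount. Read in reverse, chloro in place of methyl is expected to raise the number modestly. The steps of a number 1.22 log units higher from compound 1 to compound 2 (beyond the scatter) and a number 0.84 log units higher from compound 1 to compound 3 (beyond the scatter) show the same order, chloro above methyl at that position. Going by the values given here, no measured step tells how the position ortho to the fused ring responds.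

For compound 4 a modest rise beyond the scatter is therefore expected, a number 0.30 log units higher from compound 2 to compound 4 (within the scatter). The estimate for compound 4 in this assay is 7, with a range from 6.5 to 7.5.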

Compound 4, negative logarithm of the half-maximal effective concentration: 6.51
Compound 4: middle estimate off by 0.49 log units, on the high side; the measured number falls inside the stated range.
By their numbers in this assay, from the lowest: compound 1; then compounds 3, 4 and 2 (each within the scatter of the next, the first and the last beyond it).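

In this assay, the step of a number 0.19 log units lower from compound 2 to compound 4 (within the scatter) shows that chloro in place of methyl, on the aromatic carbon ortho to a fused ring, gives two numbers that cannot be told apart. The earlier compounds shown here showed the same exchange of groups only at the other substituted carbon, where the step of a number 0.38 log units lower from compound 2 to compound 3 (beyond the scatter) lies beyond the scatter, so the two positions do not answer alike to this change, and the order of chloro above methyl seen at the first position does not carry over to this one. Nothing available gives a measured reason for this difference between the two positions.

The compounds shown hold only methyl and chloro on the carbon ortho to a fused ring, so it stays open how that position would respond to a methoxy group, an amine or a carboxylic acid, or to plain hydrogen alongside the chloro group of compound 2. On these data alone, it also stays open whether methyl and chloro would remain this close there if the chloro group meta to that carbon gave way to a methyl group or a hydrogen.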